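This account rests on a few compounds, and the source may have more. Where it says the series, first, only, none or still open, it means among the compounds named here.

Measured in a functional assay on MCF7 cells (Homo sapiens) for antiproliferative activity, read by MTT assay, with a stated time of 72 h; a lower number here means a stronger inhibitor, a higher number a weaker inhibitor:
- Compound 1 `CC(C)c1ccc(NCC(=O)N[C@H]2CCOC2=O)cc1`: > 64000 nM
- Compound 2 `Cc1cc(Cl)ccc1NCC(=O)N[C@H]1CCOC1=O`: > 64000 nM
- Compound 3 `O=C(CNc1ccccc1)N[C@H]1CCOC1=O`: > 64000 nM

All three entries are limits of the assay, not numbers. Compound 3 stands only at its limit of > 64000 nM. The series as a whole shows (the limit of > 64000 nM in this assay, at which 3 of the 3 values shown sit).

Compound 4 `O=C(CNc1ccc(Cl)cc1)N[C@H]1CCOC1=O` differs from compound 3 in one place: chloro in place of hydrogen on an aromatic carbon. Among the compounds with values here, the single measured step that bears on this change has no readable size: a step that the two limits leave unreadable from compound 1 to compound 3. Compound 2, which also carries a chloro group, is likewise only a limit, > 64000 nM. No step beyond the scatter is therefore expected in this assay, in either direction. The expected change is a number no higher from compound 3 to compound 4 (the limit leaves the size open). Compound 4 is expected near 64000 nM, with an estimated range from 30000 nM to 130000 nM, and will most likely be reported only as a limit.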

Compound 4, half-maximal inhibitory concentration: > 64000 nM
Compound 4: no number, only a limit; the forecaster's own chance of this, stated with the estimate: 85%; the middle value sits exactly at the limit.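

Compound 4 is again only a limit, so its steps from compound 1, compound 2 and compound 3 cannot be read. The compounds shown leave open how any change on the aromatic ring affects potency in this assay: the limit of > 64000 nM in this assay, at which 4 of the 4 values shown sit.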